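Chalcone series: fluoro for hydrogen on the pendant ring

The source may report more compounds than this note shows. Statements on the series, on what has been measured and on what is new or still open speak of the compounds shown alone.

Compound 1 `COc1cc(OC)c(C(=O)/C=C/c2ccccc2SC)c(OC)c1`: 16%
Compound 2 `COc1cc(OC)c(C(=O)/C=C/c2ccccc2)c(OC)c1`: 23%
Compound 3 `COc1cc(O)c(C(=O)/C=C/c2ccccc2OC)c(OC)c1`: "not active" (no number reported), no number given

In a functional assay on MDA-MB-231 cells (Homo sapiens), read by fluorescence and BrdU incorporation, with a stated time of 48 h, tested at 25 uM (on this read-out higher numbers stand for a weaker effect at the one concentration tested and lower numbers for a stronger effect), compound 2 gives 23%; compound 1 sits within the scatter of it, as a number 7 percentage points higher from compound 1 to compound 2 (within the scatter) shows, so the two are not ordered. Compound 3 carries no number. Compound 4 `COc1cc(OC)c(C(=O)/C=C/c2ccc(F)cc2)c(OC)c1` differs from compound 2 by fluoro in place of hydrogen on an aromatic carbon. Going by the values given here, no measured step touches a fluoro group; the only single-place step, a number 7 percentage points higher from compound 1 to compound 2 (within the scatter), concerns methylsulfanyl and stays within the scatter. Nothing in the numbers points in either direction, so the expected step of a number 1 percentage points lower from compound 2 to compound 4 (within the scatter) is within the scatter. Compound 4 is therefore estimated at 22%, in the range 8% to 40%.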

Compound 4, a percentage reported as activity, at one concentration (the size of the read-out at that concentration, not a potency): 10%
Estimate against measurement, compound 4: 12 percentage points above, within the range that was stated.
By their numbers in this assay, from the lowest: compounds 4, 1 and 2 (each within the scatter of the next, the first and the last beyond it).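

In this assay, going by these compounds alone, fluoro in place of hydrogen on an aromatic carbon para to a large group gives a number 13 percentage points lower from compound 2 to compound 4 (beyond the scatter) and is the first single-place step here beyond the scatter, towards a stronger effect. Replacing 2-(methylsulfanyl)phenyl by 4-fluorophenyl gives a number 6 percentage points lower from compound 1 to compound 4 (within the scatter) and leaves those two unordered. Nothing measured here explains the size of the fluoro step.

From the compounds shown here alone, whether chloro or an amine at this position would move the read-out the same way remains open. So does whether fluoro on another aromatic carbon of this ring would match this step.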